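A few compounds are considered here, and "the series" means these few. Any claim that something is new, unique, unknown or untested is made for them only; others in the source may bear on it.

In this assay, among the measured compounds shown here, (a functional assay on J774 cells (Mus musculus) for cytotoxicity, read by resazurin assay, with a stated time of 72 h; on this read-out higher numbers stand for weaker inhibition and lower numbers for stronger inhibition) compound 1 (`O=S(=O)(Nc1cccc(CO)c1)c1ccc(-c2ccc3cc[nH]c3c2)cc1`) gives 2500 nM, which is the only plain number among the two values shown. Compound 2 (`O=C(Nc1cccc(CO)c1)c1ccc(-c2ccc(F)cc2F)cc1`) returns only a limit of the assay, > 15000 nM, and not a number. Compound 3 (`O=S(=O)(Nc1cccc(CO)c1)c1ccc(-c2ccc(Cl)cc2F)cc1`) differs from compound 1 in one place: 4-chloro-2-fluorophenyl in place of 1H-indol-6-yl on an aromatic carbon. No measured step of this kind is shown, so the direction rests on the structural change alone; a move toward weaker inhibition is expected, as a 3.2-fold higher number from compound 1 to compound 3 (0.51 log units; beyond the scatter). Compound 3 is therefore estimated at 8000 nM, within a range from 2500 nM to 15000 nM, and a limit remains possible given (the limit of > 15000 nM in this assay, at which 1 of the 2 values shown sits).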

Compound 3, half-maximal inhibitory concentration: 700 nM
Beside the measured number, compound 3's estimate is 11-fold (1.06 log units) above it; the measured number lies below the stated range.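

In this assay, the step shows that this aromatic carbon, para to a large group, responds to the group it carries: 4-chloro-2-fluorophenyl in place of 1H-indol-6-yl gives a 3.6-fold lower number from compound 1 to compound 3 (0.55 log units; beyond the scatter). Stronger inhibition is thus reached with a single six-membered aromatic ring of carbon only, and the five-membered ring and its hydrogen-bond donor are not required for it. Nothing shown gives a cause for this step.

The compounds shown leave open whether the chlorine, the fluorine or the phenyl ring itself carries the change. As far as these compounds go, how an unsubstituted phenyl or a pyridyl group would read at this place also stays open.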